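The compounds below may be only part of what the source reports. "The series", "measured", "known", "first", "only" and "open" are said of these compounds alone.

The three measured compounds share one core and differ only in the aromatic group attached to it. In a functional assay on CHO-K1 cells with Glucose-dependent insulinotropic receptor (Homo sapiens) as the target, read by a luciferase reporter, with a stated time of 5 h (a lower number here means a smaller maximal response, a higher number a larger maximal response), compound 1 `CC(C)OC(=O)N1CCC(Oc2ncnc3c2CCN3c2ccc(S(C)(=O)=O)cc2)CC1` gives 154%. Compound 2 `CC(C)OC(=O)N1CCC(Oc2ncnc3c2CCN3c2ccc([S+]([O-])N(C)C)cc2)CC1` gives 128% in this assay, a number 26 percentage points lower from compound 1 to compound 2 (beyond the scatter). Compound 3 `CSc1ccc(N2CCc3c(OC4CCN(C(=O)OC(C)C)CC4)ncnc32)cc1F` gives 121% in this assay, the lowest of the three numbers, with a number 33 percentage points lower from compound 1 to compound 3 (beyond the scatter) and a number 7 percentage points lower from compound 2 to compound 3 (within the scatter). Compound 4 `Cc1cc(S(C)(=O)=O)ccc1N1CCc2c(OC3CCN(C(=O)OC(C)C)CC3)ncnc21` is not yet measured; it differs from compound 3 in one place: a group of 11 heavy atoms (8 carbon, 2 oxygen, 1 sulfur; one six-membered aromatic ring of carbon only) in place of a group of 9 heavy atoms (7 carbon, 1 fluorine, 1 sulfur; one six-membered aromatic ring of carbon only), on a nitrogen on an aromatic ring in a ring. Within the data shown here, the change brings back the methylsulfonyl group found in compound 1, so the step of a number 33 percentage points lower from compound 1 to compound 3 (beyond the scatter) bears on it most directly, though the entering methyl has no measured counterpart. A rise is therefore expected, a number 24 percentage points higher from compound 3 to compound 4 (beyond the scatter). Compound 4 is estimated at 145%, within a range from 120% to 170%.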

Compound 4, largest response reached (reported as percent of maximum), in percent of the reference or control that the assay uses: 80%
Compound 4: middle estimate off by 65 percentage points, on the high side; measured number outside the range, below it.
By their numbers in this assay, from the lowest: compound 4; then compounds 3 and 2 (each within the scatter of the next); then compound 1.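

In this assay, swapping a single hydrogen on an aromatic carbon for methyl gives a number 74 percentage points lower from compound 1 to compound 4 (beyond the scatter), so this small change alone moves the maximal response a long way. The other two steps point the same way, a number 41 percentage points lower from compound 3 to compound 4 (beyond the scatter) and a number 48 percentage points lower from compound 2 to compound 4 (beyond the scatter), which shows that the methylsulfonyl group does not by itself secure a high number. No available evidence accounts for this fall. On these data alone, whether a chlorine atom or an ethyl group on that same aromatic carbon would lower the number as well remains open.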